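Phenyl for (pyridin-2-yl)methyl on an amide-type nitrogen

This account rests on a few compounds, and the source may have more. Where it says the series, first, only, none or still open, it means among the compounds named here.

Compound 1 `N[C@H]1CC[C@H](Nc2c(C(=O)NCc3ccco3)nc(Br)c3cccnc23)CC1` gives > 10000 nM
Compound 2 `N[C@H]1CC[C@H](Nc2c(C(=O)NCc3ccccn3)nc(Br)c3cccnc23)CC1` gives "not determined" (no result reported)

In a functional assay on HCT-116 cells (Homo sapiens) for cytotoxicity, read by MTT assay, with a stated time of 72 h (a lower number here means a stronger inhibitor, a higher number a weaker inhibitor), the entry for compound 2 reads "not determined" (no result reported) and holds no number. Compound 1 shows > 10000 nM and this is a limit, not a number. Among the compounds with values here, the only reference point for compound 2 is therefore the limit of > 10000 nM in this assay, at which 1 of the 2 values shown sits, and nothing firmer.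

Compound 3 `N[C@H]1CC[C@H](Nc2c(C(=O)Nc3ccccc3)nc(Br)c3cccnc23)CC1` has not yet been measured. The change is phenyl in place of (pyridin-2-yl)methyl on an amide-type nitrogen, with phenyl in place of (pyridin-2-yl)methyl on an amide-type nitrogen. Within the data shown here, no measured step exists to size this change, so none beyond the scatter is expected in this assay. For compound 3 the estimated value is 12000 nM with an expected range of 3000 nM to 50000 nM.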

Compound 3, half-maximal inhibitory concentration: 2000 nM
The estimate for compound 3 lay 6.0-fold (0.78 log units) above the measured number; the whole stated range lies above it.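

In this assay, the group on this amide-type nitrogen clearly matters: phenyl in place of (furan-2-yl)methyl gives an at least 5.0-fold lower number from compound 1 to compound 3 (0.69 log units; beyond the scatter). Within the data shown here, compound 3 therefore provides the first firm number in this small set. The true size of the step remains unknown, as the value for compound 1 is a limit: the limit of > 10000 nM in this assay, at which 1 of the 3 values shown sits.

Among these compounds, compound 2 has no result, so no step involving it can be read. On these data alone, what a benzyl group on the same nitrogen would give stays open, and with it whether the ring itself or the carbon linking it to the nitrogen matters more.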